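The compounds below may be only part of what the source reports. "The series", "measured", "known", "first", "only" and "open" are said of these compounds alone.

Working notes on the series. Going by the values given here, compound 1 `NC(=O)Cn1c(-c2ccc(C(F)(F)F)cc2)nc2cccnc21` and compound 2 `CCN(CC)C(=O)Cn1c(-c2ccc(Cl)cc2)nc2cccnc21` share one core and differ at two places, the substituent on the pendant aryl ring and the amide nitrogen, so no single step between them is counted here. In a functional assay on the whole organism with Mus musculus as the target (on this read-out lower numbers stand for an effect already at smaller amounts and higher numbers for an effect only at larger amounts of compound), compound 1 gives 11.7 mg/kg, and compound 2 gives 16 mg/kg in the same read-out. The two numbers lie within the usual scatter of each other, so compound 2 is not separated from compound 1 by this assay.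

Compound 3 `CN(C)CCCNC(=O)Cn1c(-c2ccc(Cl)cc2)nc2cccnc21` is not yet measured. It keeps the aryl chloride of compound 2 and changes only the amide nitrogen: (3-(dimethylamino)propyl)amino in place of diethylamino on a carbonyl carbon. Among the compounds with values here, no measured pair in this set reports such an exchange, so the size of the step is unknown; the expectation is a step of no size beyond the scatter, a 1.2-fold lower number from compound 2 to compound 3 (0.09 log units; within the scatter). Compound 3 is therefore estimated at 13 mg/kg in this assay, in a range from 5 mg/kg to 35 mg/kg.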

Compound 3, dose for half-maximal effect: 64 mg/kg
For compound 3 the middle estimate is 4.9-fold (0.69 log units) below the measured one; the whole stated range lies below it.
By their numbers in this assay, from the lowest: compounds 1 and 2 (each within the scatter of the next); then compound 3.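

Going by these compounds alone, the amide nitrogen is the first place where a single change can be read: in this assay the exchange gives a 4.0-fold higher number from compound 2 to compound 3 (0.60 log units; beyond the scatter) with the aryl chloride kept. This position therefore does not tolerate every group equally, as (3-(dimethylamino)propyl)amino on the carbonyl carbon gives a step beyond the scatter where compound 1 and compound 2 could not be separated. No measurement available here bears on the reason for this step.

Which feature of the entering group carries the step remains open: the amide hydrogen, the chain or the terminal dimethylamino. A shorter chain ending in dimethylamino, a propylamino without the terminal amine, or a morpholine at the chain end would separate these features.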